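Moving a fluorine on the shared core: compound 1 to compound 4

This account rests on a few compounds, and the source may have more. Where it says the series, first, only, none or still open, it means among the compounds named here.

Three compounds have been measured in an ADME assay on the whole organism for pharmacokinetics, with Rattus norvegicus as the target, at a dose of 1 mg/kg by the oral route; on this read-out higher numbers stand for higher exposure at the dose given and lower numbers for lower exposure:

- compound 1 `CC(C)CC1(O)CCN(C(=O)Nc2cc(Oc3ccc(C(=O)O)cc3)cc(Oc3ccc(F)cc3F)c2)CC1` gives 18.5 nM
- compound 2 `CC(C)CC1(O)CCN(C(=O)Nc2cc(Oc3ccc(F)cc3)cc(Oc3ccc(C4(C(=O)O)CC4)cc3)c2)CC1` gives 110 nM
- compound 3 `CC(C)CC1(O)CN(C(=O)Nc2cc(Oc3ccc(F)cc3)cc(Oc3ccc(C(C)(C)C(=O)O)cc3)c2)C1` gives 738 nM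

Among these three, compound 1 stands lowest in this assay. Compound 2 is the nearest to it, with a number higher than that of compound 1 by a step beyond the scatter, and compound 3 is the furthest, higher again by a step well beyond the scatter. Compounds 2 and 3 differ from compound 1 in several places at once, so none of these gaps can be tied to a single change.

Compound 4 `CC(C)CC1(O)CCN(C(=O)Nc2cc(Oc3ccc(C(=O)O)cc3)cc(Oc3ccc(F)c(F)c3)c2)CC1` is the one not yet measured. It keeps every atom of compound 1 and changes only where two fluorine atoms sit on one ring: 3,4-difluorophenyl in place of 2,4-difluorophenyl on an oxygen on an aromatic ring. Among the measured compounds shown here, no pair of measured compounds shows what such a rearrangement does in this assay. With the same atoms and groups retained, the expectation is a step no larger than the scatter in either direction, and compound 4 is estimated at 25 nM, within 6 nM to 100 nM. That expectation means a step of a 1.4-fold higher number from compound 1 to compound 4 (0.13 log units; within the scatter), essentially flat.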

Compound 4, maximal plasma concentration: 22.2 nM
Estimate against measurement, compound 4: 1.1-fold (0.05 log units) above; measured number inside the range.
By their numbers in this assay, from the lowest: compounds 1 and 4 (each within the scatter of the next); then compound 2; then compound 3.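

Swapping 2,4-difluorophenyl for 3,4-difluorophenyl on an oxygen on an aromatic ring gives the first comparison here that isolates a single change in this assay, and the step is small: a 1.2-fold higher number from compound 1 to compound 4 (0.08 log units; within the scatter). At this place, then, the two arrangements of the fluorine atoms cannot be told apart by this read-out, even though the atoms and the counts of the group stay the same and only the way they are joined differs. Nothing available here explains this result or says what lies behind it.

Going by these compounds, this single pair speaks only for these two difluorophenyl groups on the core of compound 1, so it remains open whether a different group on the same ring, such as a nitrile, a methoxy group or a trifluoromethyl group, would leave the number just as undisturbed. On these data alone, it also remains open whether the same fluorine swap would be as quiet alongside the other parts carried by compound 2 and compound 3, whose higher numbers still cannot be tied to any single change.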